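Isobutyl to isopropyl on the amine nitrogen

The source may hold more compounds than are shown below. What is called first, only, known or untested is meant among the compounds shown, and "the series" means these compounds.

In a functional assay on SK-BR-3 cells (Homo sapiens) for antiproliferative activity (a higher number here means a weaker inhibitor, a lower number a stronger inhibitor), compound 1 (`CCCNCCCOc1ccc2cc(NC(=O)c3ccc(O)c(CC=C(C)C)c3)c(=O)oc2c1C`) gives 990 nM and compound 2 (`CC(C)=CCc1cc(C(=O)Nc2cc3ccc(OCCCNCC(C)C)c(C)c3oc2=O)ccc1O`) gives 1030 nM. These two values lie within the scatter of each other, so compound 2 stands level with compound 1. Compound 3 (`CC(C)=CCc1cc(C(=O)Nc2cc3ccc(OCCCNC(C)C)c(C)c3oc2=O)ccc1O`) carries isopropyl in place of isobutyl on an amine nitrogen. Among the measured compounds shown here, only one measured step bears on this change, and it also alters the group on that nitrogen. That step is a 1.0-fold higher number from compound 1 to compound 2 (0.02 log units; within the scatter), with methyl in place of hydrogen on a saturated chain carbon bound to two saturated chain carbons, and it stays within the scatter. On that single step, no shift beyond the scatter is expected in this assay. The expected step is a 1.0-fold lower number from compound 2 to compound 3 (0.01 log units; within the scatter). The estimate for compound 3 is 1000 nM, with an expected range of 550 nM to 1800 nM.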

Compound 3, half-maximal inhibitory concentration: 750 nM
Estimate against measurement, compound 3: 1.3-fold (0.12 log units) above, within the range that was stated.
By their numbers in this assay, from the lowest: compounds 3, 1 and 2 (each within the scatter of the next).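

In this assay, isopropyl in place of isobutyl on the amine nitrogen gives a 1.4-fold lower number from compound 2 to compound 3 (0.14 log units; within the scatter), and isopropyl in place of propyl on the same nitrogen gives a 1.3-fold lower number from compound 1 to compound 3 (0.12 log units; within the scatter). The earlier pair covered only propyl and isobutyl, so isopropyl adds a third group on this nitrogen, and all three steps among these compounds lie within the scatter. Across propyl, isobutyl and isopropyl, this position therefore gives no separation in this assay.

Still open, on these data alone, is whether a markedly different group on this nitrogen, such as a cyclohexyl ring, a longer chain or a hydroxyethyl group, would move the number beyond the scatter. Also open, as far as these compounds go, is whether a second substituent on the nitrogen, as in a dimethylamine, would do so. Nothing available explains the values of these compounds.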